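The source may hold more compounds than are shown below. What is called first, only, known or untested is meant among the compounds shown, and "the series" means these compounds.

Four closely related compounds share one core, a sugar-bearing bicyclic base that carries a benzyl-type side arm on a nitrogen, and differ only in the aromatic ring at the end of that arm. Compound 1 `OC[C@H]1O[C@@H](n2cnc3c(NCc4ccccc4Br)ncnc32)[C@H](O)[C@@H]1O` carries a 2-bromophenyl ring, compound 2 `Cc1ccc(CNc2ncnc3c2ncn3[C@@H]2O[C@H](CO)[C@@H](O)[C@H]2O)cc1` a 4-methylphenyl ring, compound 3 `OC[C@H]1O[C@@H](n2cnc3c(NCc4cccc(O)c4O)ncnc32)[C@H](O)[C@@H]1O` a 2,3-dihydroxyphenyl ring, and compound 4 `Cc1cccc(CNc2ncnc3c2ncn3[C@@H]2O[C@H](CO)[C@@H](O)[C@H]2O)c1O` a 2-hydroxy-3-methylphenyl ring.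

In a functional assay on G-361 cells (Homo sapiens) for antiproliferative activity, with a stated time of 72 h (on this read-out lower numbers stand for stronger inhibition and higher numbers for weaker inhibition), compound 1 gives only a limit, > 166000 nM, not a number. In this assay compound 3 gives 16900 nM. For compound 2 the entry in this assay is "not determined" (no result reported), so compound 2 has no number to stand on; it is known here only through its structure.

Among the measured compounds shown here, the one measured step, an at least 9.8-fold lower number from compound 1 to compound 3 (0.99 log units; beyond the scatter), shows that a ring carrying hydroxyl groups reached a number, while the bromine-bearing ring did not, as the limit of > 166000 nM in this assay, at which 1 of the 3 values shown sits, records. The step from compound 2 to compound 4 also brings a hydroxyl group onto the ring: 2-hydroxy-3-methylphenyl in place of 4-methylphenyl on a saturated chain carbon bound to a nitrogen on an aromatic ring. Compound 4 is thus the closest relative of compound 3, trading one hydroxyl for a methyl group. Since compound 2 has no number, no size of step can be expected; the estimate for compound 4 instead leans on compound 3 and its value 16900 nM. Compound 4 is expected to give about 20000 nM, within 5000 nM to 80000 nM.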

Compound 4, half-maximal inhibitory concentration: > 166000 nM
Compound 4 was reported as a limit; the forecaster's own chance of this, stated with the estimate: 20%; middle value at least 8.3-fold (0.91 log units) from the limit.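

In this assay, putting methyl in place of hydroxy on an aromatic carbon gives an at least 9.8-fold higher number from compound 3 to compound 4 (0.99 log units; beyond the scatter), so one small change on the ring separates a compound that reaches a number from one that does not. Compound 4 keeps a hydroxyl group on its ring and still gives only a limit, so a single hydroxyl group did not suffice here, and the earlier contrast between a hydroxyl-bearing ring and a bromine-bearing ring does not hold as a simple rule: the limit of > 166000 nM in this assay, at which 2 of the 4 values shown sit. Compound 1 and compound 4 both end at limits, so the step between them cannot be read.

On these data alone, it remains open whether the second hydroxyl group of compound 3 matters as such, since only a methyl group stands in its place here, and an amino group or a methoxy group on that carbon would give a further comparison. Also open is whether any other ring can improve on compound 3, which at 16900 nM is the only compound shown with a number, leaving a single value to build on.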